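A few compounds are considered here, and "the series" means these few. Any claim that something is new, unique, unknown or untested is made for them only; others in the source may bear on it.

Measured so far in a functional assay on Rec1 cells (Homo sapiens) for inhibition, read by luminescence and CellTiter-Glo, with a stated time of 72 h; on this read-out higher numbers stand for weaker inhibition and lower numbers for stronger inhibition:

compound 1 `O=C(O)c1cc(-c2ccc(Oc3ccccc3)cc2)nn1C1CCCN(C(=O)CCl)C1` — 2200 nM
compound 2 `O=C(CCl)Nc1ccc(Cn2nc(-c3ccc(Oc4ccccc4)cc3)cc2C(=O)O)cc1` — 4000 nM
compound 3 `CCOC(=O)c1cc(-c2ccc(Oc3ccccc3)cc2)nn1C1CCCN(C(=O)CCl)C1` — 400 nM

Compound 1 and compound 2 sit within the usual scatter of each other in this assay, so no order is read from them. Compound 3 lies apart from both. Compound 1 and compound 3 share a core and differ in one place only: ethyl in place of hydrogen on an oxygen next to a carbonyl group. This gave a 5.5-fold lower number from compound 1 to compound 3 (0.74 log units; beyond the scatter) in this assay, a modest step, yet clearly beyond the scatter.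

Compound 2 carries a different core from compound 1; the difference between the two cores is not broken down here. Compound 2 shows only the acid form, and the corresponding ester is compound 4 `CCOC(=O)c1cc(-c2ccc(Oc3ccccc3)cc2)nn1Cc1ccc(NC(=O)CCl)cc1`, which has not yet been measured in this assay. Its change from compound 2 is ethyl in place of hydrogen on an oxygen next to a carbonyl group, and the place of the change is described in the same words as for the pair of compound 1 and compound 3, so this is the same change, now made on the second core. The change occurs twice among the compounds shown, once measured and once not.

Among the compounds with values here, for compound 4 the step of a 5.5-fold lower number from compound 2 to compound 4 (0.74 log units; beyond the scatter) is expected in this assay, because a 5.5-fold lower number from compound 1 to compound 3 (0.74 log units; beyond the scatter) is the one measured instance of this change and compound 2 offers the only point of departure on its core. Compound 4 is estimated at 730 nM, with a range from 300 nM to 1800 nM; the range is kept wide since the change has been seen on one core only.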

Compound 4, half-maximal inhibitory concentration: 400 nM
For compound 4 the middle estimate is 1.8-fold (0.26 log units) above the measured one; the range from low to high includes it.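

In this assay, the change from carboxy to ethoxycarbonyl on the second core gives a 10-fold lower number from compound 2 to compound 4 (1.00 log units; beyond the scatter), so the number falls on both cores, and the two steps cannot be told apart in size: the same change on two cores in this assay, a 5.5-fold lower number (0.74 log units; beyond the scatter) from compound 1 to compound 3 and a 10-fold lower number (1.00 log units; beyond the scatter) from compound 2 to compound 4, 1.8-fold (0.26 log units) apart, within the scatter of two such steps.
For this pair of cores, then, the change carries over, and the step seen on the core of compound 1 matches the one on the core of compound 2 in direction and, within the scatter, in size. Two cores are still a narrow base: the result does not show that the step would hold on a further core, and these numbers alone give no reason why the ethyl esters give the lower numbers.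

The compounds shown leave open whether the step is tied to ethyl or would also appear with methyl, with a longer chain such as butyl, or with a primary amide in place of the ethoxycarbonyl group. Also open, as far as these compounds go, is how much the chloroacetamide group, present in every compound here, contributes, which an acrylamide or a plain acetamide in its place would begin to address.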